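Furan-3-yl in Place of Thiophen-3-yl on the Shared Core

A few compounds are considered here, and "the series" means these few. Any claim that something is new, unique, unknown or untested is made for them only; others in the source may bear on it.

Measured compounds in an assay on HEK293 cells for displacement of a labelled ligand from adenosine receptor A2b (Homo sapiens), with a stated time of 30 min; on this read-out higher numbers stand for weaker inhibition and lower numbers for stronger inhibition:
- compound 1, `CCOC(=O)C1=C(C)N/C(=N\C#N)NC1c1ccsc1`, 461 nM
- compound 2, `CC1=C(C(=O)OC(C)C)[C@@H](c2ccco2)N/C(=N/C#N)N1`, 15.1 nM
- compound 3, `CC1=C(C(=O)OC(C)C)C(c2cccs2)N/C(=N/C#N)N1`, 349 nM

Compound 1 gives the highest number of the three in this assay. Its nearest neighbour is compound 3, whose value lies within the scatter of that of compound 1, so no order between the two is claimed. The furthest is compound 2, whose number is beyond the scatter below that of compound 1, by a wide margin.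

Compound 4, `CCOC(=O)C1=C(C)N/C(=N\C#N)NC1c1ccoc1`, is the next compound to be measured in this assay. It is related to compound 1 by a single change: furan-3-yl in place of thiophen-3-yl on a saturated ring carbon. For the measured compounds named here, no step between two measured compounds traces exactly this exchange, so the expectation rests only on the values shown. Going by the values given here, compound 2 gives the lowest number of the set, and compound 2 is the one measured compound that carries a furan ring; this is the sole pointer available, and it is a weak one since compound 2 and compound 3 are not a one-change pair with compound 1.

On that basis the step from compound 1 to compound 4 is expected to be a 4.6-fold lower number from compound 1 to compound 4 (0.66 log units; beyond the scatter), towards a lower number, beyond the scatter but smaller than the gap between compound 1 and compound 2. Compound 4 is thus estimated at 100 nM, with a range from 30 nM to 400 nM.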

Compound 4, inhibition constant: 102 nM
For compound 4 the middle estimate is 1.0-fold (0.01 log units) below the measured one; the measured number falls inside the stated range.
By their numbers in this assay, from the lowest: compound 2; then compound 4; then compounds 3 and 1 (each within the scatter of the next).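

For the compounds shown here, the first one-change step, in this assay, is a 4.5-fold lower number from compound 1 to compound 4 (0.66 log units; beyond the scatter). This shows that the saturated ring carbon of the shared core is sensitive to the identity of its five-membered aromatic ring, since the number moves beyond the scatter when sulfur gives way to oxygen while the counted heavy atoms, donors and acceptors stay the same. Nothing available explains why this exchange lowers the number.

From the compounds shown here alone, whether the step carries over to the isopropyl ester of compound 2 and compound 3, or depends on the ethoxycarbonyl group of compound 1 and compound 4, remains open. Also open, going by these compounds, is how a phenyl or pyridin-3-yl ring on the same carbon would compare with furan-3-yl.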